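Removing the Carbamoyl Group from Compound 1

A few compounds are considered here, and "the series" means these few. Any claim that something is new, unique, unknown or untested is made for them only; others in the source may bear on it.

In an assay on cells for binding affinity to Myc proto-oncogene protein (Homo sapiens) (a lower number here means a stronger inhibitor, a higher number a weaker inhibitor), the three measured compounds stand as follows:

compound 1 `N#Cc1ccc(-c2cc(-c3ccc(C(N)=O)cc3)cc(-c3ccco3)n2)cc1` — 3000 nM
compound 2 `Cn1ccnc1-c1cc(-c2ccc(C(N)=O)cc2)cc(-c2ccc(C#N)cc2)n1` — 40000 nM
compound 3 `NC(=O)c1ccc(-c2cc(-c3ccc(-c4cnco4)cc3)nc(-c3ccco3)c2)cc1` — 2500 nM

Compound 1 holds the second highest of the three numbers. Its nearest neighbour is compound 3, reached by a 1.2-fold lower number from compound 1 to compound 3 (0.08 log units; within the scatter), a step within the scatter; the furthest is compound 2, reached by a 13-fold higher number from compound 1 to compound 2 (1.12 log units; beyond the scatter), a step well beyond it.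

Compound 4 `N#Cc1ccc(-c2cc(-c3ccccc3)cc(-c3ccco3)n2)cc1` differs from compound 1 in one place: hydrogen in place of carbamoyl on an aromatic carbon. Both measured steps from compound 1 concern other positions of the shared core, the furan-2-yl ring in the step to compound 2 and the cyano group in the step to compound 3, so neither bears directly on the carbamoyl. The data thus give no measured guide for this change, and the expectation rests on the change itself. The author expects a modest weakening, a 2.0-fold higher number from compound 1 to compound 4 (0.30 log units; within the scatter), with compound 4 estimated at 6000 nM in this assay, within a range from 1500 nM to 30000 nM.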

Compound 4, half-maximal inhibitory concentration: 5000 nM
Beside the measured number, compound 4's estimate is 1.2-fold (0.08 log units) above it, and the stated range covers the measured number.
By their numbers in this assay, from the lowest: compounds 3, 1 and 4 (each within the scatter of the next); then compound 2.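

Replacing 4-carbamoylphenyl with phenyl gives a 1.7-fold higher number from compound 1 to compound 4 (0.22 log units; within the scatter) in this assay, so at this place the carbamoyl, with its hydrogen-bond donor and acceptor, can go without a shift that stands out from the scatter. This step differs in size from the one at the furan-2-yl position, a 13-fold higher number from compound 1 to compound 2 (1.12 log units; beyond the scatter), which is beyond the scatter, and it gives the first reading at this position among the compounds shown. No supporting measurement bears on why the carbamoyl contributes so little here.

Still open, as far as these compounds go, is how an amine, a carboxylic acid or a longer chain would behave at this same place on the ring. The compounds shown also leave open whether the carbamoyl could be lost equally well in compound 2 or compound 3, where the shared core carries a different group.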